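The compounds below may be only part of what the source reports. "The series", "measured", "known", "first", "only" and "open" are said of these compounds alone.

Three compounds share one core and differ only in the group on the outer benzene ring. Compound 1 `COc1ccc(Nc2nccc(-c3cccnc3)n2)cc1` carries a methoxy group, compound 2 `CCc1ccc(Nc2nccc(-c3ccccn3)n2)cc1` an ethyl group and compound 3 `CC(=O)Nc1ccc(Nc2nccc(-c3ccccn3)n2)cc1` an acetamido group. In a functional assay for inhibition, with Homo sapiens as the target (on this read-out higher numbers stand for weaker inhibition and lower numbers for stronger inhibition), compound 1 gives 1700 nM, compound 2 gives 2100 nM and compound 3 gives 1500 nM. For the measured compounds named here, compound 3 has the lowest of the three numbers, but every gap to it is within the scatter, so no compound can be called stronger or weaker than another here. Going by the values given here, the one single-point step that was measured, a 1.4-fold lower number from compound 2 to compound 3 (0.15 log units; within the scatter), is also within the scatter.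

Compound 4 `COc1ccc(Nc2nccc(-c3ccccn3)n2)cc1` is the next compound, and the change from compound 3 is methoxy in place of acetamido on an aromatic carbon. Two things bear on it. The step from compound 2 to compound 3 shows that swapping the group at this place moved the number very little. Compound 1 also carries a methoxy group at the same place and gives a number within the scatter of compound 3, though compound 1 differs elsewhere as well, so it is only a pointer. Compound 4 is therefore expected to give a step of a 1.1-fold higher number from compound 3 to compound 4 (0.05 log units; within the scatter) in this assay that stays within the scatter. The estimate for compound 4 is 1700 nM, expected to fall between 800 nM and 3600 nM.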

Compound 4, half-maximal inhibitory concentration: 8300 nM
Compound 4: the middle estimate sits 4.9-fold (0.69 log units) below what was measured; measured number outside the range, above it.
By their numbers in this assay, from the lowest: compounds 3, 1 and 2 (each within the scatter of the next); then compound 4.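

In this assay this position turns out not to be indifferent to its group: the step of a 5.5-fold higher number from compound 3 to compound 4 (0.74 log units; beyond the scatter) and the step of a 4.0-fold higher number from compound 2 to compound 4 (0.60 log units; beyond the scatter) are both beyond the scatter, while the step of a 1.4-fold lower number from compound 2 to compound 3 (0.15 log units; within the scatter) is within it. Methoxy therefore parts from both acetamido and ethyl here, even though those two groups cannot be told apart from each other. The position of the nitrogen in the pyridine also matters when methoxy is held fixed, as the step of a 4.9-fold higher number from compound 1 to compound 4 (0.69 log units; beyond the scatter) for pyridin-2-yl in place of pyridin-3-yl shows, and nothing available here explains either kind of step.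

The compounds shown cannot say whether the higher number belongs to methoxy alone or would also appear with a hydroxyl, an ethoxy group or an amine at this place. They also leave open whether pyridin-3-yl in place of pyridin-2-yl would give a similar step when acetamido or ethyl sits on the outer benzene ring.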